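Series notes: aryl swap on the amine nitrogen

The compounds below may be only part of what the source reports. "The series", "measured", "known", "first", "only" and "open" are said of these compounds alone.

Measured so far:
compound 1, `CCOC(=O)C1=C(C)NC(=S)NC1c1cn(C(=O)CNc2ccccc2)c2ccccc12`: 2.92
compound 2, `CCOC(=O)C1=C(C)NC(=S)NC1c1cn(C(=O)CNc2ccc([N+](=O)[O-])cc2)c2ccccc12`: 2.88

In a physicochemical assay for lipophilicity (on this read-out higher numbers stand for higher lipophilicity and lower numbers for lower lipophilicity), compound 2 holds the lowest of the two numbers; its nearest neighbour is compound 1, and the step of a number 0.04 log units lower from compound 1 to compound 2 (within the scatter) lies within the scatter, so the two cannot be ordered.

Compound 3, `CCOC(=O)C1=C(C)NC(=S)NC1c1cn(C(=O)CNc2ccccc2N)c2ccccc12`, has not yet been measured in this assay. It differs from compound 2 by 2-aminophenyl in place of 4-nitrophenyl on an amine nitrogen. Among the measured compounds shown here, of the measured steps only the one from compound 1 to compound 2 bears on it, and that step covers the nitro alone; it was within the scatter. For the measured compounds named here, the entering 2-aminophenyl has no measured counterpart, so the expectation rests on undoing the nitro step plus an unsupported allowance for the amino, and the range is kept wide. Compound 3 is estimated at 2.3, range 1.8 to 2.8. The step of a number 0.58 log units lower from compound 2 to compound 3 (beyond the scatter) is accordingly expected to run downward.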

Compound 3, partition coefficient: 2.14
Estimate against measurement, compound 3: 0.16 log units above; the range from low to high includes it.
By their numbers in this assay, from the lowest: compound 3; then compounds 2 and 1 (each within the scatter of the next).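

In this assay, the aryl group on the amine nitrogen is no longer a silent position: adding an amino group to the phenyl ring gives a number 0.78 log units lower from compound 1 to compound 3 (beyond the scatter), whereas nitro in place of hydrogen gave only a number 0.04 log units lower from compound 1 to compound 2 (within the scatter). The swap of 4-nitrophenyl for 2-aminophenyl on the same nitrogen gives a number 0.74 log units lower from compound 2 to compound 3 (beyond the scatter), so the number here depends on which group the phenyl ring carries or where it carries it. Nothing available explains this step.

The compounds shown do not separate the identity of the group from its place on the ring, so a 4-aminophenyl analogue would be the direct comparison with both 2-aminophenyl and 4-nitrophenyl. As far as these compounds go, how a methoxy group or a carboxylic acid on the same phenyl ring would read remains open.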